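An ester chain swap and its expected toxicity

The compounds below may be only part of what the source reports. "The series", "measured", "known", "first", "only" and "open" are said of these compounds alone.

In an ADME assay on HepG2 2.2.15 cells (Homo sapiens) for cytotoxicity (on this read-out higher numbers stand for lower toxicity in this test and lower numbers for higher toxicity in this test), compound 1 `C=CCn1c(=O)c(CCO)c(-c2ccccc2Cl)c2cc(Cl)ccc21` gives 23000 nM and compound 2 `CC(=O)OCCc1c(-c2ccccc2Cl)c2cc(Cl)ccc2[nH]c1=O` gives 27000 nM. Compound 3 `CCCCC(=O)OCCc1c(-c2ccccc2Cl)c2cc(Cl)ccc2[nH]c1=O` gives the highest number of the three at 200000 nM, making it the least toxic of them in this assay. Compound 4 `CCOCC(=O)OCCc1c(-c2ccccc2Cl)c2cc(Cl)ccc2[nH]c1=O` keeps everything in compound 3 except one part of its chain, with ethoxy in place of propyl on a saturated chain carbon bound to a carbonyl carbon. For the measured compounds named here, only one measured step bears on this change: propyl in place of hydrogen at that same place, a 7.4-fold higher number from compound 2 to compound 3 (0.87 log units; beyond the scatter), which is beyond the scatter. Going by the values given here, no measured compound carries ethoxy, so this step is only a rough guide. Compound 4 keeps a chain at that carbon, yet it loses the propyl that came with the rise, so a modest fall is expected, smaller than the rise itself. The expected step is a 2.2-fold lower number from compound 3 to compound 4 (0.35 log units; beyond the scatter). Compound 4 is estimated at 90000 nM, with an expected range from 30000 nM to 200000 nM.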

Compound 4, half-maximal cytotoxic concentration: 130000 nM
Estimate against measurement, compound 4: 1.4-fold (0.16 log units) below, and the stated range covers the measured number.
By their numbers in this assay, from the lowest: compounds 1 and 2 (each within the scatter of the next); then compounds 4 and 3 (each within the scatter of the next).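

In this assay the oxygen-containing ethoxy and the all-carbon propyl on this saturated chain carbon bound to a carbonyl carbon cannot be told apart (a 1.5-fold lower number from compound 3 to compound 4 (0.19 log units; within the scatter)). The rise seen earlier with propyl is therefore not confined to an all-carbon chain, as ethoxy in place of hydrogen also gives a higher number (a 4.8-fold higher number from compound 2 to compound 4 (0.68 log units; beyond the scatter)). No measurement here explains why either chain goes with a higher number than hydrogen. These compounds leave open whether a longer chain, such as hexyl, would raise the number further or whether the rise would level off. They also leave open whether an amine or a carboxylic acid at the end of the chain would keep the number as high as ethoxy does.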